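Swapping the phenyl substituent on a flavone-like core

The compounds below may be only part of what the source reports. "The series", "measured", "known", "first", "only" and "open" are said of these compounds alone.

Measured so far:
compound 1, `COc1c(OCCCCN2CCN(C)CC2)cc(O)c2c(=O)cc(-c3ccc(C)cc3)oc12`, 3810 nM
compound 2, `COc1c(OCCCCN2CCN(C)CC2)cc(O)c2c(=O)cc(-c3ccc(C(F)(F)F)cc3)oc12`, 2890 nM
compound 3, `COc1c(OCCCCN2CCN(C)CC2)cc(O)c2c(=O)cc(-c3ccc([N+](=O)[O-])cc3)oc12`, 3210 nM

All three share the same core and differ only in the group carried by the phenyl ring on the aromatic carbon next to the ring oxygen. In a functional assay on A549 cells (Homo sapiens) for cytotoxicity, read by MTT assay, with a stated time of 72 h (a lower number here means a stronger inhibitor, a higher number a weaker inhibitor), the three numbers sit close together: the step of a 1.3-fold lower number from compound 1 to compound 2 (0.12 log units; within the scatter), the step of a 1.2-fold lower number from compound 1 to compound 3 (0.07 log units; within the scatter) and the step of a 1.1-fold higher number from compound 2 to compound 3 (0.05 log units; within the scatter) all lie within the scatter, so nothing separates compound 3 from compound 1 or compound 2 in this assay.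

Compound 4, `COc1ccccc1-c1cc(=O)c2c(O)cc(OCCCCN3CCN(C)CC3)c(OC)c2o1`, is not yet measured. It differs from compound 3 by 2-methoxyphenyl in place of 4-nitrophenyl on an aromatic carbon. Among the compounds with values here, none of the measured steps covers a change of this kind, since each of them kept a phenyl ring bearing a group of the same placement and only traded one such group for another; all those trades stayed within the scatter. Within the data shown here, the only evidence at hand is that three different phenyl substituents gave indistinguishable numbers, so the expected step, a 1.0-fold higher number from compound 3 to compound 4 (0.01 log units; within the scatter), is none beyond the scatter. Compound 4 is therefore estimated to give 3300 nM in this assay, with a range from 1500 nM to 7500 nM.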

Compound 4, half-maximal inhibitory concentration: 6790 nM
Beside the measured number, compound 4's estimate is 2.1-fold (0.31 log units) below it; the measured number falls inside the stated range.
By their numbers in this assay, from the lowest: compounds 2, 3, 1 and 4 (each within the scatter of the next, the first and the last beyond it).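

In this assay, this position turns out not to be indifferent to every change, as the earlier trades among para-style groups might have suggested: the 2-methoxyphenyl group gives the first differences here that pass the scatter, with a 2.1-fold higher number from compound 3 to compound 4 (0.33 log units; beyond the scatter) and a 2.3-fold higher number from compound 2 to compound 4 (0.37 log units; beyond the scatter) both beyond it, though only modestly. Against compound 1 the picture is softer, since a 1.8-fold higher number from compound 1 to compound 4 (0.25 log units; within the scatter) does not clear the scatter, so compound 4 stands apart from only two of the three earlier compounds and cannot be called the weakest of the four. No measurement at hand offers a reason for this shift.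

Compound 4 changes both the group on the phenyl ring and where that group sits, so the compounds shown cannot tell whether the methoxy group itself or its placement in 2-methoxyphenyl lies behind the higher number. From the compounds shown here alone, how a phenyl ring carrying an amine or a carboxylic acid would fall also stays open.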